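A Methoxy Group on the Aromatic Ring of Compound 3

A few compounds are considered here, and "the series" means these few. Any claim that something is new, unique, unknown or untested is made for them only; others in the source may bear on it.

Measured so far:
Compound 1, `CC(C)C[C@@H]1C[C@H](Cl)C[C@H](CC(C)C)O1`: 89000 nM
Compound 2, `CC(C)C[C@H]1C[C@@H](Cl)C[C@@H](C2CCCCC2)O1`: 43000 nM
Compound 3, `CC(C)C[C@H]1C[C@@H](Cl)C[C@@H](c2ccccc2)O1`: 48000 nM

All three compounds share one core and differ only in the group on its far side. In a functional assay on SW1573 cells (Homo sapiens) for antiproliferative activity (a higher number here means a weaker inhibitor of growth, a lower number a stronger inhibitor of growth), compound 3 gives 48000 nM, the second highest of the three numbers. Its nearest neighbour is compound 2 with 43000 nM, and the furthest is compound 1 with 89000 nM; both gaps lie within the scatter of repeated measurements, so the three compounds cannot be told apart on these numbers.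

Compound 4, `COc1ccc([C@@H]2C[C@H](Cl)C[C@H](CC(C)C)O2)cc1`, has not been measured yet. It differs from compound 3 in one place: methoxy in place of hydrogen on an aromatic carbon, on an aromatic carbon of a six-membered aromatic ring of carbon only, para to a large group. For the measured compounds named here, no measured pair shows the effect of such a change here, so no step size can be read from the data. With all three measured compounds sitting in one narrow band, a small step is expected for compound 4, with no clear direction beyond the scatter; the step from compound 3 is estimated as a 1.2-fold lower number from compound 3 to compound 4 (0.08 log units; within the scatter). Compound 4 is therefore expected to give about 40000 nM, likely between 15000 nM and 120000 nM.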

Compound 4, concentration for total growth inhibition: 80000 nM
Compound 4: middle estimate off by 2.0-fold (0.30 log units), on the low side, within the range that was stated.
By their numbers in this assay, from the lowest: compounds 2, 3, 4 and 1 (each within the scatter of the next, the first and the last beyond it).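

Methoxy in place of hydrogen on an aromatic carbon gives the only step in this set that can be read directly, and in this assay it amounts to a 1.7-fold higher number from compound 3 to compound 4 (0.22 log units; within the scatter) and so cannot be told apart from no change at all. At this place, para to a large group, adding methoxy with its 2 heavy atoms and 1 hydrogen-bond acceptor gives no sign of either a gain or a loss in growth inhibition. Nothing in the data offers an explanation for this result.

As far as these compounds go, whether a different group at this same place, such as an amine, a carboxylic acid or a longer chain, would move the number beyond the scatter remains open. Also open, from the compounds shown here alone, is whether methoxy would behave the same way on another carbon of that ring, and one step at one place cannot settle this.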